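Swapping the Indane for a Trifluoromethylthio Phenyl

This account rests on a few compounds, and the source may have more. Where it says the series, first, only, none or still open, it means among the compounds named here.

Of the compounds shown here, two have been measured in an in vitro assay on BHK cells for displacement of a labelled ligand from gastric inhibitory polypeptide receptor (Homo sapiens), read by scintillation proximity assay; a lower number here means a stronger inhibitor, a higher number a weaker inhibitor. Compound 1 `O=C(O)CCNC(=O)c1ccc(CN(c2ccc3c(c2)CCC3)c2nc(-c3ccc(C(F)(F)F)cc3)cs2)cc1` gives 1100 nM and stands at the upper end of the two numbers. Compound 2 `O=C(NC[C@@H](O)C(=O)O)c1ccc(CC(c2ccc(OC(F)(F)F)cc2)c2nc(-c3ccc(C(F)(F)F)cc3)cs2)cc1` gives 565 nM, a value within the scatter of compound 1. Compound 3 `O=C(O)CCNC(=O)c1ccc(CN(c2ccc(SC(F)(F)F)cc2)c2nc(-c3ccc(C(F)(F)F)cc3)cs2)cc1` differs from compound 1 in one place: 4-((trifluoromethyl)sulfanyl)phenyl in place of 2,3-dihydro-1H-inden-5-yl on a nitrogen on an aromatic ring. Among the measured compounds shown here, no measured pair shows this change, so its effect is unknown; a modest gain is expected in this assay, with the estimated step being a 1.7-fold lower number from compound 1 to compound 3 (0.23 log units; within the scatter), though nothing beyond the scatter is assured. Compound 3 is expected to give about 650 nM, within 200 nM to 2200 nM.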

Compound 3, half-maximal inhibitory concentration: 777 nM
Compound 3: the middle estimate sits 1.2-fold (0.08 log units) below what was measured; the range from low to high includes it.
By their numbers in this assay, from the lowest: compounds 2, 3 and 1 (each within the scatter of the next).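

Among the compounds shown here, this is the only single-place step so far in this assay: 4-((trifluoromethyl)sulfanyl)phenyl in place of 2,3-dihydro-1H-inden-5-yl on a nitrogen on an aromatic ring gives a 1.4-fold lower number from compound 1 to compound 3 (0.15 log units; within the scatter) and so no change that can be told from the scatter. At this position, a group with a five-membered non-aromatic ring and a group with a sulfur and three fluorines read alike. No supporting measurement explains this result. On these data alone, whether a phenyl ring carrying an amine at this position would also read alike remains open.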